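The compounds below may be only part of what the source reports. "The series", "measured", "known", "first", "only" and "open" are said of these compounds alone.

In an ADME assay on HeLa cells (Homo sapiens) for cytotoxicity, read by LDH release, with a stated time of 24 h (a lower number here means a stronger inhibitor, a higher number a weaker inhibitor), compound 1 (`C#CCNCc1ccc2c(Br)cc(Br)c(O)c2n1`) gives > 25000 nM as a limit of the assay and not a number. Compound 2 (`CC(C)(C)OC(=O)N1CCN(Cc2ccc3c(Br)cc(Br)c(O)c3n2)CC1`) gives > 100000 nM as a limit too. Compound 1 therefore stands at a limit, with no measured number to place it more exactly. Compound 3 (`CCCNCc1ccc2c(Br)cc(Br)c(O)c2n1`) has ethyl in place of ethynyl on a saturated chain carbon bound to an amine nitrogen, which turns propargyl into propyl. Going by the values given here, no measured step speaks to this change, so the expected shift (a step that the limit leaves unreadable from compound 1 to compound 3) is none beyond the scatter. For compound 3 the estimated value is 30000 nM with an expected range (10000 nM to 100000 nM).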

Compound 3, half-maximal inhibitory concentration: > 100000 nM
Compound 3: no number, only a limit; the forecaster's own chance of this, stated with the estimate: 65%; middle value at least 3.3-fold (0.52 log units) from the limit.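

Compound 1 and compound 3 each give only a limit in this assay, not a number, so no step can be read between them. The compounds shown leave open whether ethyl in place of ethynyl shifts the value at all, and by how much.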